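Swapping a cyanomethyl ether for a chlorobenzyl ether

A few compounds are considered here, and "the series" means these few. Any claim that something is new, unique, unknown or untested is made for them only; others in the source may bear on it.

Three close relatives of one core have been tested in an ADME assay on HEL cells (Homo sapiens) for cytotoxicity, with a stated time of 3 days (a higher number here means that more compound is tolerated, a lower number that less compound is tolerated), and the question is what a fourth will do. Compound 1 `CCC1(Cc2ccccc2)OS(=O)(=O)C=C1OCC#N` carries a cyanomethyl ether on its core. In this assay compound 1 reaches only a limit, > 200000 nM, so for it no number is known. This is the assay limit (the limit of > 200000 nM in this assay, at which 1 of the 3 values shown sits). Compound 2 `CCC1(Cc2ccccc2)OS(=O)(=O)CC1=O` replaces the ether with a ketone and gives 200000 nM in this assay. Compound 3 `CC(C)CC1(Cc2ccccc2)OS(=O)(=O)C=C1OCc1ccccc1` carries a benzyl ether together with an isobutyl group in place of the ethyl group, and in this assay compound 3 gives 102000 nM; the values of compound 2 and compound 3 sit within the usual scatter of each other.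

The new compound 4 `CCC1(Cc2ccccc2)OS(=O)(=O)C=C1OCc1cccc(Cl)c1` differs from compound 1 in one place: 3-chlorophenyl in place of cyano on a saturated chain carbon bound to an oxygen on an unsaturated carbon. Among the compounds with values here, no step between measured compounds matches this change, so the expectation rests on the values above. Compound 3, the only measured benzyl ether, gives 102000 nM, which suggests a modest move. The step from compound 1 to compound 4 is expected to be an at least 2.0-fold lower number from compound 1 to compound 4 (0.30 log units; that floor lies within the scatter), toward less tolerated compound. For compound 4 the estimate is 100000 nM, with a range from 40000 nM to 200000 nM.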

Compound 4, half-maximal cytotoxic concentration: 50000 nM
The estimate for compound 4 lay 2.0-fold (0.30 log units) above the measured number, within the range that was stated.
By their numbers in this assay, from the lowest: compound 4; then compounds 3 and 2 (each within the scatter of the next).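

Replacing cyano with 3-chlorophenyl on a saturated chain carbon bound to an oxygen on an unsaturated carbon gives, in this assay, an at least 4.0-fold lower number from compound 1 to compound 4 (0.60 log units; beyond the scatter). Within the data shown here, this is the first change at a single place that can be read, and it shows that this position on the shared core can shift how much compound the cells tolerate by more than the usual scatter. Compound 1 gives only a limit, > 200000 nM, so the step is a floor and its full size remains unknown: the limit of > 200000 nM in this assay, at which 1 of the 4 values shown sits.

The swap brings in an aromatic ring and a chlorine together, so the compounds shown leave open how much of the step belongs to the ring and how much to the chlorine. Also open, as far as these compounds go, is what a different group on the same chain carbon, such as an amine, a carboxylic acid or a longer chain, would do in this assay.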